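The source may hold more compounds than are shown below. What is called first, only, known or untested is meant among the compounds shown, and "the series" means these compounds.

Compound 1, `O=C(CCCCc1ccccc1)CC(=O)N[C@H]1CCOC1=O`, in a functional assay on NCI-H630 cells (Homo sapiens) for cytotoxicity, read by sulforhodamine B assay, with a stated time of 5 days (a lower number here means a stronger inhibitor, a higher number a weaker inhibitor), gives only a limit, > 100000 nM.
Compound 2, `O=C(CCCCCCc1ccccc1)CC(=O)N[C@H]1CCOC1=O`, gives in this assay 65000 nM.
Compound 3, `O=C(CCCCCCCc1ccccc1)CC(=O)N[C@H]1CCOC1=O`, gives in this assay 42000 nM.

The three measured compounds share a core and differ in the group on the saturated chain. The value of compound 1 sits at the limit of > 100000 nM in this assay, at which 1 of the 3 values shown sits, so its distance to the others is not fully known. The change from compound 1 to compound 2 is phenethyl in place of phenyl on a saturated chain carbon, four bonds along the chain from a carbonyl carbon, and it gives an at least 1.5-fold lower number from compound 1 to compound 2 (0.18 log units; that floor lies within the scatter). From compound 2 to compound 3, benzyl in place of phenyl on a saturated chain carbon, six bonds along the chain from a carbonyl carbon, gives a 1.5-fold lower number from compound 2 to compound 3 (0.19 log units; within the scatter). Compound 3 has the lowest number of the two numbers available, but its gap to compound 2 lies within the scatter, so no order between them can be claimed. The difference between the cores of compound 1 and compound 3 is not broken down here.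

Compound 4, `O=C(CCCCCCCCCc1ccccc1)CC(=O)N[C@H]1CCOC1=O`, has not been measured. It differs from compound 3 by phenethyl in place of phenyl on a saturated chain carbon, seven bonds along the chain from a carbonyl carbon. This is the same kind of change as that from compound 1 to compound 2, but the place differs: four bonds along the chain from a carbonyl carbon there, seven bonds here. For compound 4 in this assay a step of a 1.7-fold lower number from compound 3 to compound 4 (0.23 log units; within the scatter) is expected, resting on the small steps of an at least 1.5-fold lower number from compound 1 to compound 2 (0.18 log units; that floor lies within the scatter) and a 1.5-fold lower number from compound 2 to compound 3 (0.19 log units; within the scatter), both within the scatter. Compound 4 is thus estimated at 25000 nM, between 10000 nM and 60000 nM.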

Compound 4, half-maximal inhibitory concentration: 16000 nM
Compound 4: middle estimate off by 1.6-fold (0.19 log units), on the high side, within the range that was stated.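

Phenethyl in place of phenyl, seven bonds along the chain from a carbonyl carbon, gives in this assay a 2.6-fold lower number from compound 3 to compound 4 (0.42 log units; beyond the scatter). Over two changes taken together, 3-phenylpropyl in place of phenyl, six bonds along the chain from a carbonyl carbon, gives a 4.1-fold lower number from compound 2 to compound 4 (0.61 log units; beyond the scatter).

The same change therefore points the same way on two cores, and on the core of compound 3 its effect stands clear of the scatter, but this does not show that it has the same size on both: the same change on two cores in this assay, an at least 1.5-fold lower number (0.18 log units; that floor lies within the scatter) from compound 1 to compound 2 and a 2.6-fold lower number (0.42 log units; beyond the scatter) from compound 3 to compound 4; the limit leaves it open whether they differ. Compound 1 gives only a limit, so its pair supplies a floor for the step and not a measured size: the limit of > 100000 nM in this assay, at which 1 of the 4 values shown sits. Carrying the change from one core to another is thus supported in direction by these two pairs alone, and nothing firmer can be said about its size.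

The compounds shown leave open whether a longer chain than that of compound 4 would lower the number further in this assay or whether the fall would stop. They also leave open how the series would respond if the phenyl end of the chain carried an amine or a carboxylic acid.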